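Phenyl added to compound 2: outlook for compound 3

The source may report more compounds than this note shows. Statements on the series, on what has been measured and on what is new or still open speak of the compounds shown alone.

Measured so far:
compound 1, `O=C(Nc1cnncc1C(=O)O)c1ccc(SC(F)(F)F)cc1`, an assay on isolated protein for activation of potassium channel subfamily K member 10 (Homo sapiens), read by thallium flux; on this read-out lower numbers stand for an effect already at smaller amounts and higher numbers for an effect only at larger amounts of compound: "not determined" (no result reported)
compound 2, `O=C(Nc1sccc1C(=O)O)c1ccc(SC(F)(F)F)cc1`, this assay: > 30000 nM

Compound 1 carries no result in this assay. As far as these compounds go, compound 2 reaches only the assay limit in this assay, namely > 30000 nM, so its true position is unknown beyond that boundary; see (the limit of > 30000 nM in this assay, at which 1 of the 2 values shown sits). Of the two entries shown, one is a limit and the other carries no number, so no measured step exists and nothing can be said about how any change has moved the read-out.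

Compound 3, `O=C(Nc1sc(-c2ccccc2)cc1C(=O)O)c1ccc(SC(F)(F)F)cc1`, is the next compound in the series and differs from compound 2 by phenyl in place of hydrogen on an aromatic carbon, the phenyl entering on an aromatic carbon of a five-membered aromatic ring with 1 sulfur, next to the ring sulfur. Within the data shown here, with no comparable step to lean on, the only fixed point is the limit of compound 2. The change is expected to bring a modest gain at most, and the outcome for compound 3 may well remain at the limit again. For compound 3 the estimated value is 20000 nM, with a range from 3000 nM to 100000 nM, which would correspond to a step of an at least 1.5-fold lower number from compound 2 to compound 3 (0.17 log units; that floor lies within the scatter).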

Compound 3, half-maximal effective concentration: > 30000 nM
Compound 3: a limit, no number (the forecaster's own chance of this, stated with the estimate: 60%); middle value at least 1.5-fold (0.17 log units) from the limit.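

In this assay compound 3 gives > 30000 nM, a limit and not a number. No step from compound 2 to compound 3 can be read, since both stop at the assay limit: the limit of > 30000 nM in this assay, at which 2 of the 3 values shown sit.

The compounds shown leave open whether phenyl in place of hydrogen on this aromatic carbon shifts the read-out at all.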